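Swapping one side group on compound 3

The source may hold more compounds than are shown below. What is called first, only, known or untested is meant among the compounds shown, and "the series" means these compounds.

Values so far in an ADME assay on microsomes from liver (Mus musculus) for metabolic stability, read by LC-MS, using NADPH, with stated times of 10 min and 30 min, tested at 1 uM; a lower number here means slower removal, a higher number faster removal of the compound
Compound 1 `COC(=O)C1=C(C)NC(c2nccs2)=NC1(C)c1ccc(S(C)(=O)=O)cc1` gives 57 mL/min/kg
Compound 2 `COC(=O)C1=C(C)NC(c2nccs2)=NC1(C)c1ccc(F)c(F)c1` gives 83 mL/min/kg
Compound 3 `COC(=O)C1=C(CN2CCNC(=O)C2)NC(c2nccs2)=NC1(C)c1ccc(F)cc1` gives 81 mL/min/kg

Compound 3 at 81 mL/min/kg lies within the usual scatter of both other compounds, so these numbers do not set it apart from them. Compound 4 `COC(=O)C1=C(Cn2ccnc2)NC(c2nccs2)=NC1(C)c1ccc(F)cc1` differs from it in one place: 1H-imidazol-1-yl in place of 3-oxopiperazin-1-yl on a saturated chain carbon bound to a double-bonded ring carbon. Among the measured compounds shown here, no two measured compounds differ in only one place, so the data show no comparable step. In this assay the expected outcome is a 1.1-fold lower number from compound 3 to compound 4 (0.05 log units; within the scatter) (no step beyond the scatter). For compound 4 the estimated clearance is 72 mL/min/kg (expected range 42 mL/min/kg to 110 mL/min/kg).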

Compound 4, clearance: 69 mL/min/kg
Beside the measured number, compound 4's estimate is 1.0-fold (0.02 log units) above it, within the range that was stated.
By their numbers in this assay, from the lowest: compounds 1, 4, 3 and 2 (each within the scatter of the next).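

In this assay, among the compounds shown here, putting 1H-imidazol-1-yl in place of 3-oxopiperazin-1-yl on this saturated chain carbon gives a 1.2-fold lower number from compound 3 to compound 4 (0.07 log units; within the scatter) and so offers the first one-place comparison in this set. At this position, a five-membered aromatic ring can replace a six-membered non-aromatic ring, with the loss of the hydrogen-bond donor, without a step beyond the scatter. No available measurement points to a cause for this result. Still open, on these data alone, is whether an open-chain amine such as dimethylamino or a carboxylic acid at this position would give a step beyond the scatter. A longer chain carrying the imidazole is equally untested by the compounds shown.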